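Removing the methyl from the chloro-methylphenyl urea

The source may report more compounds than this note shows. Statements on the series, on what has been measured and on what is new or still open speak of the compounds shown alone.

Three ureas on one shared core have been measured in a functional assay on HepG2 cells (Homo sapiens) for antiproliferative activity, read by MTT assay, with a stated time of 48 h; a lower number here means a stronger inhibitor, a higher number a weaker inhibitor. Compound 1 `Cc1ccc(NC(=O)Nc2cccc(CNc3nccnc3Cl)c2)cc1` gives 11500 nM, compound 2 `Cc1ccc(NC(=O)Nc2cccc(CNc3nccnc3Cl)c2)cc1Cl` gives 11300 nM, and compound 3 `O=C(Nc1cccc(CNc2nccnc2Cl)c1)Nc1ccc(Cl)c(Cl)c1` gives 6170 nM. Compound 2 stands second highest of the three numbers, with compound 1 nearest and compound 3 furthest, and all three lie within the scatter of one another. The steps are correspondingly small: a 1.0-fold lower number from compound 1 to compound 2 (0.01 log units; within the scatter), a 1.8-fold lower number from compound 2 to compound 3 (0.26 log units; within the scatter) and a 1.9-fold lower number from compound 1 to compound 3 (0.27 log units; within the scatter). Nothing beyond the scatter has yet been seen on this aryl urea side of the core.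

Compound 4 `O=C(Nc1cccc(Cl)c1)Nc1cccc(CNc2nccnc2Cl)c1` is the next member. Its difference from compound 2 is: hydrogen in place of methyl on an aromatic carbon. Among the measured compounds shown here, no measured step exchanges a methyl for hydrogen. The two that bear on it are the step from compound 1 to compound 2, where chloro entered at an aromatic carbon, and the step from compound 2 to compound 3, where chloro replaced the methyl at this same carbon; both stayed within the scatter. On that basis the expected step of a 1.1-fold lower number from compound 2 to compound 4 (0.03 log units; within the scatter) is none beyond the scatter. Compound 4 is therefore estimated at 10500 nM, with a range of 5000 nM to 22000 nM.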

Compound 4, half-maximal inhibitory concentration: 9140 nM
The estimate for compound 4 lay 1.1-fold (0.06 log units) above the measured number, within the range that was stated.
By their numbers in this assay, from the lowest: compounds 3, 4, 2 and 1 (each within the scatter of the next).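

At the carbon para to a large group and ortho to a chloro group, hydrogen now stands alongside methyl and chloro, and the steps are a 1.2-fold lower number from compound 2 to compound 4 (0.09 log units; within the scatter) and a 1.5-fold higher number from compound 3 to compound 4 (0.17 log units; within the scatter), so all three groups at this carbon give numbers within the scatter of one another in this assay. The 3-chlorophenyl urea can also be set against the 4-methylphenyl urea, with a 1.3-fold lower number from compound 1 to compound 4 (0.10 log units; within the scatter), so this exchange of aryl groups likewise shows no separation. Compound 4 also makes it possible to read chloro entering an aromatic carbon on two cores, one carrying a methyl and one carrying hydrogen at the neighbouring substituted position of the series, and the two readings agree within the scatter: the same change on two cores in this assay, a 1.0-fold lower number (0.01 log units; within the scatter) from compound 1 to compound 2 and a 1.5-fold lower number (0.17 log units; within the scatter) from compound 4 to compound 3, 1.5-fold (0.16 log units) apart, within the scatter of two such steps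

As far as these compounds go, whether any group at this carbon can move the number beyond the scatter remains open, for example methoxy, an amine or a carboxylic acid. The compounds shown differ only in the aryl group of the urea, so the effect of changing the shared core, such as an amine in place of its chloro group, also remains open.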